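Methyl in Place of Methoxy: an Estimate for Compound 4

The source may hold more compounds than are shown below. What is called first, only, known or untested is meant among the compounds shown, and "the series" means these compounds.

Of the compounds shown here, three sharing one core have been measured in an ADME assay on HeLa cells (Homo sapiens) for cytotoxicity, read by microscopy; on this read-out higher numbers stand for lower toxicity in this test and lower numbers for higher toxicity in this test. Compound 1 `CSc1nc(NCCCCNc2ccnc3cc(Cl)ccc23)c(C#N)c(-c2ccccc2)n1` gives 100000 nM, compound 2 `CSc1nc(NCCCCNc2ccnc3cc(Cl)ccc23)c(C#N)c(-c2ccc([N+](=O)[O-])cc2)n1` gives 4000 nM, and compound 3 `COc1ccc(-c2nc(SC)nc(NCCCCNc3ccnc4cc(Cl)ccc34)c2C#N)cc1` gives 20000 nM. Compound 3 thus stands second highest of the three numbers: its nearest neighbour is compound 1, from which a 5.0-fold lower number from compound 1 to compound 3 (0.70 log units; beyond the scatter), and its furthest is compound 2, with a 5.0-fold higher number from compound 2 to compound 3 (0.70 log units; beyond the scatter). The larger step in this set is a 25-fold lower number from compound 1 to compound 2 (1.40 log units; beyond the scatter).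

Compound 4 `CSc1nc(NCCCCNc2ccnc3cc(Cl)ccc23)c(C#N)c(-c2ccc(C)cc2)n1` differs from compound 3 in one place: methyl in place of methoxy on an aromatic carbon. Within the data shown here, no measured step swaps methyl for any other group, so only the three steps above bear on the question, and they show that a single group on this ring can shift the number by a modest to large amount in this assay. With nothing to tie a methyl to either end of that span, compound 4 is expected to land near compound 3 or somewhat toward compound 1, with a step estimated at a 1.5-fold higher number from compound 3 to compound 4 (0.18 log units; within the scatter). The number expected for compound 4 in this assay is therefore 30000 nM, in a range from 10000 nM to 100000 nM.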

Compound 4, minimum cytotoxic concentration: 100000 nM
Beside the measured number, compound 4's estimate is 3.3-fold (0.52 log units) below it; the measured number falls inside the stated range.
By their numbers in this assay, from the lowest: compound 2; then compound 3; then compounds 1 and 4 (each within the scatter of the next).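

Within this assay, putting methyl on this aromatic carbon in place of methoxy gives a 5.0-fold higher number from compound 3 to compound 4 (0.70 log units; beyond the scatter), and putting it in place of nitro gives a 25-fold higher number from compound 2 to compound 4 (1.40 log units; beyond the scatter), so the number at this position depends on which group is present and not merely on whether a group sits para to a large group. Against the unsubstituted ring, methyl gives no change at the digits printed from compound 1 to compound 4 (within the scatter): among the groups shown, a substituent here does not always lower the number, since methoxy and nitro do so while methyl does not. No measurement accompanying these compounds accounts for the difference between methyl and methoxy, so the result describes the change without explaining it.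

As far as these compounds go, it remains open whether other groups at this place, such as an ethyl group, a chlorine atom, an amine or a carboxylic acid, would stay with hydrogen and methyl or move toward methoxy and nitro. From the compounds shown here alone, it also remains open whether methyl would match hydrogen in the same way on a different carbon of this ring or on a changed version of the shared core.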